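From phenethyl to 4-chlorophenyl on the sulfur

A few compounds are considered here, and "the series" means these few. Any claim that something is new, unique, unknown or untested is made for them only; others in the source may bear on it.

Compound 1 `Cc1ccc(SCc2ccc(C(=O)Nc3ccccc3N)cc2)cc1` gives 25.1%
Compound 2 `Nc1ccccc1NC(=O)c1ccc(CSc2ccc(Br)cc2)cc1` gives 10%
Compound 3 `Nc1ccccc1NC(=O)c1ccc(CSCCc2ccccc2)cc1` gives 28.1%

All three values come from a functional assay on SMMC-7721 cells (Homo sapiens) for inhibition, read by CCK-8 assay, with a stated time of 72 h, tested at 2 uM (on this read-out higher numbers stand for more inhibition of growth at the one concentration tested and lower numbers for less inhibition of growth), and the compounds differ only in the group on the sulfur. Compound 3 cannot be told apart from compound 1, as shown by a number 3 percentage points higher from compound 1 to compound 3 (within the scatter). It clearly exceeds compound 2, as shown by a number 18.1 percentage points higher from compound 2 to compound 3 (beyond the scatter).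

The next compound is compound 4 `Nc1ccccc1NC(=O)c1ccc(CSc2ccc(Cl)cc2)cc1`, which has not yet been measured. The change is 4-chlorophenyl in place of phenethyl on a sulfur. This gives compound 4 a 4-substituted phenyl group on the sulfur, as in compounds 1 and 2, so those two are the best guides. Compound 2, with its 4-bromophenyl group, is the closest relative, and reversing a number 18.1 percentage points higher from compound 2 to compound 3 (beyond the scatter) points to a clear fall. Compound 1 points to almost no change, given a number 3 percentage points higher from compound 1 to compound 3 (within the scatter). Among the compounds with values here, the gap between these two guides is a number 15.1 percentage points lower from compound 1 to compound 2 (beyond the scatter), and no chloro compound has been measured to show which one compound 4 will follow. A modest downward step is therefore expected, leaning towards compound 2, and the estimated move is a number 12.1 percentage points lower from compound 3 to compound 4 (beyond the scatter). For compound 4 the estimated value is 16%, with an expected range from 6% to 29%.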

Compound 4, percent growth inhibition at one concentration: 2.93%
The estimate for compound 4 lay 13.1 percentage points above the measured number; measured number outside the range, below it.
By their numbers in this assay, from the lowest: compounds 4 and 2 (each within the scatter of the next); then compounds 1 and 3 (each within the scatter of the next).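

In this assay, putting 4-chlorophenyl in place of phenethyl on the sulfur gives a number 25.2 percentage points lower from compound 3 to compound 4 (beyond the scatter), a clear loss of growth inhibition. Chloro in place of bromo on the aromatic carbon gives a number 7.1 percentage points lower from compound 2 to compound 4 (within the scatter), while chloro in place of methyl gives a number 22.2 percentage points lower from compound 1 to compound 4 (beyond the scatter), so the new compound groups with the bromo compound and not with the methyl compound. The low number of the bromo compound is therefore no longer a single case: among these four compounds, both halogen-bearing rings on the sulfur sit low, while the methyl-bearing ring stays level with phenethyl, and no compound shown goes against this. Nothing available here explains why the halogens and the methyl group part ways.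

Going by these compounds, it remains open whether a methoxy group or an amine in place of the chloro on the aromatic carbon would group with the halogens or with methyl. On these data alone, it is also open whether a chloro on the ring of the phenethyl group would lower the number as it does when the ring sits directly on the sulfur.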